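The compounds below may be only part of what the source reports. "The series", "measured", "known", "first", "only" and "open" are said of these compounds alone.

Measured in a functional assay on SK-OV-3 cells (Homo sapiens) for inhibition, read by MTT assay; a higher number here means a weaker inhibitor, a lower number a stronger inhibitor:
- Compound 1 `COc1ccc2c(c1)CC[C@H](O)/C2=C/c1cc(OC)c(OC)c(OC)c1`: 1 nM
- Compound 2 `COc1ccc(/C=C2\c3cc(OC)c(OC)c(OC)c3CC[C@@H]2O)cc1F`: 1 nM

Compound 2 stands level with compound 1 at the digits shown, and the two values lie within the usual scatter of repeat measurements. Compound 3 `COc1ccc(/C=C2\c3cc(OC)c(OC)c(OC)c3CC[C@@H]2O)cc1N` has amino in place of fluoro on an aromatic carbon, ortho to a methoxy group (amino in place of fluoro on an aromatic carbon). Among the measured compounds shown here, no measured pair shows a single change of this kind, so the expectation starts from compound 2 at 1 nM, with no step beyond the scatter expected in this assay. The estimated change a 1.5-fold higher number from compound 2 to compound 3 (0.18 log units; within the scatter) is small, in the weaker direction if anything. Compound 3 is estimated at 1.5 nM, with an expected range of 0.3 nM to 10 nM.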

Compound 3, half-maximal inhibitory concentration: 740 nM
Estimate against measurement, compound 3: 490-fold (2.69 log units) below, outside the stated range (above it).
By their numbers in this assay, from the lowest: compounds 1 and 2 (each within the scatter of the next); then compound 3.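

Fluoro on the 3-fluoro-4-methoxyphenyl group cannot be swapped freely for amino: the change gives a 740-fold higher number from compound 2 to compound 3 (2.87 log units; beyond the scatter) even though only one heavy atom is exchanged for another. So this aromatic carbon, ortho to a methoxy group, is highly sensitive to what it carries, which the earlier values alone could not reveal. Nothing measured here explains the drop.

From the compounds shown here alone, it remains open whether only amino is poorly tolerated here or whether other groups behave the same way. A hydroxyl, a methyl, a chlorine or a plain hydrogen at this place would help separate these possibilities.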